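Phenyl for methyl on the ring nitrogen of compound 3

The source may report more compounds than this note shows. Statements on the series, on what has been measured and on what is new or still open speak of the compounds shown alone.

Measured compounds:
Compound 1, `O=C(CCCCCCc1nc2ccc(-c3cncnc3)cc2[nH]1)NO`: 2600 nM
Compound 2, `CN(C)c1ccc2nc(CCCCCCC(=O)NO)[nH]c2c1`: 1200 nM
Compound 3, `Cn1c(CCCCCCC(=O)NO)nc2ccccc21`: 3000 nM

In a functional assay on SK-OV-3 cells (Homo sapiens) for cytotoxicity (a higher number here means a weaker inhibitor, a lower number a stronger inhibitor), compound 3 gives the highest of the three numbers. Compound 1 lies close to it, within the scatter, while compound 2 gives a number that is lower beyond the scatter. Among the compounds with values here, the single step that can be traced through one change is a 2.2-fold lower number from compound 1 to compound 2 (0.34 log units; beyond the scatter). Its change sits on an aromatic carbon of the shared core and does not touch the ring nitrogen.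

Compound 4, `O=C(CCCCCCc1nc2ccccc2n1-c1ccccc1)NO`, differs from compound 3 in phenyl in place of methyl on an aromatic nitrogen. Within the data shown here, no measured pair changes the group on the aromatic nitrogen, so no step among the three compounds bears directly on this exchange. Among the measured compounds shown here, the only step known, between compound 1 and compound 2, concerns another position and was modest, which gives no ground for a large move in either direction. The expected step is therefore no change at the digits printed from compound 3 to compound 4 (within the scatter), meaning none beyond the scatter, with a wide range to cover the lack of any related step. Compound 4 is estimated at 3000 nM, within a range from 1000 nM to 9000 nM.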

Compound 4, half-maximal inhibitory concentration: > 20000 nM
Compound 4: only a limit was reported; the forecaster's own chance of this, stated with the estimate: 10%; middle value at least 6.6-fold (0.82 log units) away from the limit.
By their numbers in this assay, from the lowest: compound 2; then compounds 1 and 3 (each within the scatter of the next). At a limit, above all of these: compound 4.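

In this assay, phenyl in place of methyl on an aromatic nitrogen gives an at least 6.6-fold higher number from compound 3 to compound 4 (0.82 log units; beyond the scatter), so the first change seen at this position already moves the number beyond the scatter, and the group held here cannot be exchanged freely. Compound 4 gives > 20000 nM, which is a limit of the assay and not a number, so the step has a lower bound but no known upper end: the limit of > 20000 nM in this assay, at which 1 of the 4 values shown sits. Within the data shown here, the only earlier step, a 2.2-fold lower number from compound 1 to compound 2 (0.34 log units; beyond the scatter), lay on an aromatic carbon and said nothing about the aromatic nitrogen, whereas this one shows that a single exchange on that nitrogen, with the rest of the structure unchanged, is enough to carry the read-out to the limit.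

The compounds shown leave open whether the step follows from the added heavy atoms or from the aromatic ring itself, since an ethyl or a cyclohexyl group on this nitrogen would be needed to separate the two. They also leave open how a benzyl group, or a pyridyl ring in place of the phenyl, would read in this assay.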